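From azetidin-1-yl to dimethylamino on a carbonyl carbon

The source may report more compounds than this note shows. Statements on the series, on what has been measured and on what is new or still open speak of the compounds shown alone.

Measured in a functional assay on A20 cells (Mus musculus) for inhibition, with stated times of 1 h, 16 h and 24 h; on this read-out lower numbers stand for stronger inhibition and higher numbers for weaker inhibition:
compound 1 `N#CC1(NC(=O)[C@@H]2C[C@@H](S(=O)(=O)c3ccccc3)C[C@H]2C(=O)N2CC3CCC(C2)O3)CC1`: 16 nM
compound 2 `N#CC1(NC(=O)[C@@H]2C[C@@H](S(=O)(=O)c3ccccc3)C[C@H]2C(=O)N2CCS(=O)(=O)CC2)CC1`: 816 nM
compound 3 `N#CC1(NC(=O)[C@@H]2C[C@@H](S(=O)(=O)c3ccccc3)C[C@H]2C(=O)N2CCC2)CC1`: 44 nM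

Of these three, compound 3, at 44 nM, has the second highest number. Compound 4 `CN(C)C(=O)[C@@H]1C[C@H](S(=O)(=O)c2ccccc2)C[C@H]1C(=O)NC1(C#N)CC1` differs from it as follows: dimethylamino in place of azetidin-1-yl on a carbonyl carbon. Going by the values given here, no measured step makes this exact change, but three alter the group on the same carbonyl carbon. The large ones, a 51-fold higher number from compound 1 to compound 2 (1.71 log units; beyond the scatter) and a 19-fold lower number from compound 2 to compound 3 (1.27 log units; beyond the scatter), both involve 1,1-dioxothiomorpholin-4-yl, which compound 4 lacks. The modest one, a 2.8-fold higher number from compound 1 to compound 3 (0.44 log units; beyond the scatter), is the closer guide. A step no larger than modest is therefore expected in this assay, toward a higher number, and it may stay within the scatter. The expected step is a 1.4-fold higher number from compound 3 to compound 4 (0.13 log units; within the scatter). For compound 4 the estimated value is 60 nM, with an expected range of 25 nM to 150 nM.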

Compound 4, half-maximal inhibitory concentration: 91 nM
The estimate for compound 4 lay 1.5-fold (0.18 log units) below the measured number; the range from low to high includes it.
By their numbers in this assay, from the lowest: compound 1; then compound 3; then compound 4; then compound 2.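

In this assay, dimethylamino on this carbonyl carbon weakens inhibition relative to azetidin-1-yl (a 2.1-fold higher number from compound 3 to compound 4 (0.32 log units; beyond the scatter)), so losing the four-membered ring is not neutral here. It remains better than 1,1-dioxothiomorpholin-4-yl (a 9.0-fold lower number from compound 2 to compound 4 (0.95 log units; beyond the scatter)) but falls short of the group in compound 1 (a 5.7-fold higher number from compound 1 to compound 4 (0.75 log units; beyond the scatter)). Numbers rise as the group shrinks from compound 1 through compound 3 to compound 4, though compound 2, with as many heavy atoms as compound 1, goes against this pattern.

How a pyrrolidin-1-yl or morpholin-4-yl group on this carbonyl carbon would compare remains open, and nothing available explains these differences.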